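Three Diaryl Ureas and an Untested Methylphenyl Analogue

The compounds below may be only part of what the source reports. "The series", "measured", "known", "first", "only" and "open" are said of these compounds alone.

Measured so far in a functional assay on HepG2 cells (Homo sapiens) for antiproliferative activity, read by MTT assay, with a stated time of 48 h; on this read-out lower numbers stand for stronger inhibition and higher numbers for weaker inhibition:
compound 1, `O=C(Nc1cccc(CNc2nccnc2Cl)c1)Nc1ccc(F)c(Cl)c1`: 6750 nM
compound 2, `O=C(Nc1cccc(CNc2nccnc2Cl)c1)Nc1ccc(Cl)cc1Cl`: 7230 nM
compound 3, `O=C(Nc1cccc(CNc2nccnc2Cl)c1)Nc1cccc2ccccc12`: a limit of the assay, > 40000 nM

Compound 2 gives the highest of the two numbers; compound 1 sits nearest, within the scatter, and the third value, that of compound 3, is only a limit. Within the data shown here, the one step that joins two numbers, a 1.1-fold higher number from compound 1 to compound 2 (0.03 log units; within the scatter), swaps one chlorinated ring for another and leaves the read-out where it was. For compound 3 the read-out stands at the limit (the limit of > 40000 nM in this assay, at which 1 of the 3 values shown sits). Compound 4, `Cc1ccc(NC(=O)Nc2cccc(CNc3nccnc3Cl)c2)cc1`, is still to be tested. Its change from compound 2 is 4-methylphenyl in place of 2,4-dichlorophenyl on an amide-type nitrogen. Among the measured compounds shown here, no measured step replaces a chlorinated ring with a methylated one, so the only guide is that two chlorinated rings read alike, while the one compound without a chlorinated ring on that nitrogen, compound 3, reads as a limit. The account therefore expects the number for compound 4 to rise somewhat, a 1.7-fold higher number from compound 2 to compound 4 (0.22 log units; within the scatter), though a result within the scatter cannot be ruled out. The estimate for compound 4 is 12000 nM, with a range from 5000 nM to 40000 nM.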

Compound 4, half-maximal inhibitory concentration: 11500 nM
Compound 4: the middle estimate sits 1.0-fold (0.02 log units) above what was measured; the range from low to high includes it.
By their numbers in this assay, from the lowest: compounds 1, 2 and 4 (each within the scatter of the next). At a limit, above all of these: compound 3.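

On this amide-type nitrogen, the 4-methylphenyl ring of compound 4 carries no chlorine, yet neither step from a chlorinated ring leaves the scatter in this assay: the first is a 1.6-fold higher number from compound 2 to compound 4 (0.20 log units; within the scatter) and the second is a 1.7-fold higher number from compound 1 to compound 4 (0.23 log units; within the scatter) and so chlorine on this ring is not needed for compound 4 to give a number that cannot be told apart from those of the two chlorinated compounds. Among these compounds, compound 3, which also has no chlorine on this ring, remains the only compound at a limit, and its entry is a limit and not a number: the limit of > 40000 nM in this assay, at which 1 of the 4 values shown sits. Nothing at hand gives a measured property that would account for the steps to compound 4.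

The compounds shown leave open how a plain phenyl ring, a 4-methoxyphenyl ring or a 4-trifluoromethylphenyl ring would read on this nitrogen. They also leave open whether a ring bearing an amine or a carboxylic acid would stay with compounds 1, 2 and 4 or join compound 3 at a limit.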